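Cyclopropylmethoxy in place of pyridin-2-ylmethoxy on the shared core

The source may report more compounds than this note shows. Statements on the series, on what has been measured and on what is new or still open speak of the compounds shown alone.

Measured so far:
compound 1 `Cc1ccnc([C@@H](C)Oc2cc3oc(=O)n(CCC(=O)O)c3cc2Cl)c1`: 31600 nM
compound 2 `O=C(O)CCn1c(=O)oc2cc(OCc3ccccn3)c(Cl)cc21`: 5010 nM

Both numbers come from an assay on HEK293 cells for inhibition of kynurenine 3-monooxygenase (Homo sapiens), read by LC-MS, with a stated time of 20 h; on this read-out higher numbers stand for weaker inhibition and lower numbers for stronger inhibition. Compound 2 holds the lower of the two numbers; compound 1 lies beyond the scatter above it, so compound 2 is the stronger of the measured pair. Going by the values given here, the two also differ in more than one place, so no single step between them can be read.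

Compound 3 `O=C(O)CCn1c(=O)oc2cc(OCC3CC3)c(Cl)cc21` is not yet measured. It follows from compound 2 by one change: cyclopropyl in place of pyridin-2-yl on a saturated chain carbon bound to an oxygen on an aromatic ring.

Among the compounds with values here, no measured step covers a change of this kind, so there is no number to lean on. The expectation is a step of modest size, if any, toward a weaker number: for compound 3 the estimated step is a 1.6-fold higher number from compound 2 to compound 3 (0.20 log units; within the scatter). The estimate for compound 3 in this assay is 8000 nM, with a range from 2000 nM to 32000 nM.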

Compound 3, half-maximal inhibitory concentration: 1580 nM
Estimate against measurement, compound 3: 5.1-fold (0.70 log units) above, and the stated range ends above it.
By their numbers in this assay, from the lowest: compound 3; then compound 2; then compound 1.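

In this assay, going by these compounds alone, cyclopropyl in place of pyridin-2-yl on this saturated chain carbon bound to an oxygen on an aromatic ring gives a 3.2-fold lower number from compound 2 to compound 3 (0.50 log units; beyond the scatter), the first single change that can be read. The pyridin-2-yl ring is thus not needed at this position for inhibition on this read-out: a carbon-only three-membered ring with no hydrogen-bond acceptor serves better here. No measurement bears on why the step runs in this direction.

Still open, as far as these compounds go, is whether the lower number goes with the loss of the ring nitrogen, the loss of the aromatic ring, or the smaller group. Phenyl or cyclohexyl at the same place would help separate these readings, and this single step sets no trend for other groups.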